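Trimming the Sulfonyl Substituent of Compound 1

The source may report more compounds than this note shows. Statements on the series, on what has been measured and on what is new or still open speak of the compounds shown alone.

Compound 1 `O=S(=O)(Nc1ccc2oc(-c3ccccc3)nc2c1)c1ccccc1Cl`: > 63000 nM
Compound 2 `O=S(=O)(Nc1ccc(-c2nc3ccccc3o2)cc1)c1ccc(O)cc1`: > 63000 nM

In an assay on isolated protein for inhibition of malate dehydrogenase, mitochondrial (Sus scrofa), with stated times of 45 min and 30 min (on this read-out higher numbers stand for weaker inhibition and lower numbers for stronger inhibition), compound 1 gives only a limit, > 63000 nM. Compound 2 likewise gives only a limit in this assay, > 63000 nM. Compound 1 thus stands at the limit of > 63000 nM in this assay, at which 2 of the 2 values shown sit. On the numbers shown it is not separated from compound 2; neither shows measurable inhibition. Compound 3 `CS(=O)(=O)Nc1ccc2oc(-c3ccccc3)nc2c1` has not yet been measured. It differs from compound 1 by methyl in place of 2-chlorophenyl on a sulfonyl sulfur. Going by the values given here, no step between measured compounds is available, so the expectation rests on the shared limit alone: the step that the limit leaves unreadable from compound 1 to compound 3 is expected to stay within the scatter, with no gain beyond it. Compound 3 is therefore estimated at 100000 nM, with a range from 40000 nM to 300000 nM.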

Compound 3, half-maximal inhibitory concentration: > 63000 nM
Compound 3: a limit, no number; the forecaster's own chance of this, stated with the estimate: 85%; the middle value lies beyond the limit too.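

Compound 1 and compound 3 both give only limits in this assay, so the step between them cannot be read. The compounds shown leave open whether any group on the sulfonyl sulfur gives measurable inhibition.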